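Swapping the Aryl Group on the Amine Nitrogen

The source may report more compounds than this note shows. Statements on the series, on what has been measured and on what is new or still open speak of the compounds shown alone.

Measured so far:
compound 1, `Cc1ccc(NC2=CC(=O)c3nc4n(c3C2=O)[C@H]2OC[C@@H](O)[C@H]2OC4)cc1C`, 2080 nM in a functional assay on MCF7 cells (Homo sapiens) for inhibition, read by sulforhodamine B assay; a lower number here means a stronger inhibitor, a higher number a weaker inhibitor
compound 2, `O=C1C(Nc2cccc(Cl)c2)=CC(=O)c2c1nc1n2[C@H]2OC[C@@H](O)[C@H]2OC1`, 2970 nM
compound 3, `O=C1C(NC2CCCCC2)=CC(=O)c2c1nc1n2[C@H]2OC[C@@H](O)[C@H]2OC1`, reported only as a limit, > 16000 nM

Compound 1 and compound 2 give numbers within the usual scatter of each other, so neither can be called the stronger. Compound 3 sits at a limit, (the limit of > 16000 nM in this assay, at which 1 of the 3 values shown sits).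

Compound 4, `CCOc1ccc(NC2=CC(=O)c3nc4n(c3C2=O)[C@H]2OC[C@@H](O)[C@H]2OC4)cc1`, has not been measured. It differs from compound 1 by 4-ethoxyphenyl in place of 3,4-dimethylphenyl on an amine nitrogen.

For the measured compounds named here, the only measured step, an at least 5.3-fold higher number from compound 2 to compound 3 (0.73 log units; beyond the scatter), exchanges an aromatic ring for a saturated one; no measured pair compares two substituted phenyl rings, so it offers no guide to the change at hand. The expected step of a 1.2-fold higher number from compound 1 to compound 4 (0.08 log units; within the scatter) is therefore within the scatter. Compound 4 is estimated at 2500 nM, between 900 nM and 7000 nM.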

Compound 4, half-maximal inhibitory concentration: 1430 nM
Compound 4: the middle estimate sits 1.7-fold (0.24 log units) above what was measured; measured number inside the range.
By their numbers in this assay, from the lowest: compounds 4, 1 and 2 (each within the scatter of the next, the first and the last beyond it). At a limit, above all of these: compound 3.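

In this assay, for the compounds shown here, this is the first comparison of two substituted phenyl rings on the amine nitrogen, and the swap gives a 1.5-fold lower number from compound 1 to compound 4 (0.16 log units; within the scatter). The 4-ethoxyphenyl group brings a hydrogen-bond acceptor that 3,4-dimethylphenyl lacks, yet the number does not move beyond the scatter, so this change at this position makes no measurable difference. Nothing measured here offers an explanation for this result.

Still open, from the compounds shown here alone, is whether a phenyl ring carrying an amine or a carboxylic acid would stay in this range. The same goes for an alkoxy chain longer than ethoxy.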